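One More Link in the Chain: Compound 2 to Compound 3

This account rests on a few compounds, and the source may have more. Where it says the series, first, only, none or still open, it means among the compounds named here.

Of the compounds shown here, two have so far been tested in a functional assay on PC-3 cells (Homo sapiens) for cytotoxicity, read by sulforhodamine B assay, with a stated time of 72 h; a higher number here means a weaker inhibitor, a lower number a stronger inhibitor. Compound 1 `Ic1ccc(OCCCCCn2ccnc2)cc1` gives 27600 nM in this assay, while compound 2 `c1ccc2sc(SCCCn3ccnc3)nc2c1` gives 82600 nM. Compound 2 therefore stands at the higher of the two numbers, the weaker inhibitor of the pair, and its gap to compound 1 lies beyond the usual scatter of repeated measurements. The two compounds share neither the same core nor the same chain, so this gap cannot be traced to any single change.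

Compound 3 `c1ccc2sc(SCCCCn3ccnc3)nc2c1` differs from compound 2 in exactly one place: (1H-imidazol-1-yl)methyl in place of 1H-imidazol-1-yl on a saturated chain carbon, three bonds along the chain from a sulfur. The core and the sulfur link stay as they are. Within the data shown here, no pair of measured compounds differs in just this way, so there is no direct precedent for the size of the step. In the absence of such a precedent, the step from compound 2 to compound 3 is expected to be small, within the scatter, with no clear direction: a 1.3-fold lower number from compound 2 to compound 3 (0.10 log units; within the scatter). On that basis compound 3 is estimated at 65000 nM in this assay, with a plausible range from 25000 nM to 160000 nM.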

Compound 3, half-maximal inhibitory concentration: 82500 nM
Compound 3: middle estimate off by 1.3-fold (0.10 log units), on the low side; the range from low to high includes it.
By their numbers in this assay, from the lowest: compound 1; then compounds 3 and 2 (each within the scatter of the next).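

In this assay, putting (1H-imidazol-1-yl)methyl in place of 1H-imidazol-1-yl on a saturated chain carbon, three bonds along the chain from a sulfur, gives a 1.0-fold lower number from compound 2 to compound 3 (0.00 log units; within the scatter), so the two compounds cannot be told apart in this test. Among these compounds, this is the first comparison here in which only one place changes, whereas the earlier pair differed in both core and chain and could not isolate any single change. For this one change, at this one position, the number therefore stays within the scatter, although a single step cannot show how the chain behaves more generally, and no measurement here bears on why the step has this size.

Going by these compounds, whether the same holds for a longer chain on the shared core, or for an amine or a carboxylic acid in place of the imidazole ring, remains open. Also unresolved is what sets compound 1, at 27600 nM, apart from the other two compounds, since it differs from each of them in more than one place and no single change can be credited.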